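The source may report more compounds than this note shows. Statements on the series, on what has been measured and on what is new or still open speak of the compounds shown alone.

Compound 3 `Cc1cccc(C(=O)NCc2ccc(CNS(=O)(=O)c3ccccc3)cc2)c1` gives 1000 nM in an assay on MDA-MB-231 cells for binding affinity to C-X-C chemokine receptor type 4 (Homo sapiens), read by immunofluorescence and microscopy, with stated times of 10 min and 30 min (on this read-out higher numbers stand for an effect only at larger amounts of compound and lower numbers for an effect already at smaller amounts), the same number as compound 2 `COc1ccc(C(=O)NCc2ccc(CNS(=O)(=O)c3ccccc3)cc2)cc1` at 1000 nM; together they stand highest of the three, since compound 1 `O=C(NCc1ccc(CNS(=O)(=O)c2ccccc2)cc1)c1ccc([N+](=O)[O-])cc1` gives 100 nM, and the move a 10-fold higher number from compound 1 to compound 3 (1.00 log units; beyond the scatter) lies beyond the scatter. Compound 4 `O=C(NCc1ccc(CNS(=O)(=O)c2ccccc2)cc1)c1cccc(F)c1` differs from compound 3 by fluoro in place of methyl on an aromatic carbon. Among the measured compounds shown here, no measured step exchanges these two groups directly; the nearest comparison is no change at the digits printed from compound 2 to compound 3 (within the scatter), where the carbonyl-bound aryl ring was swapped without effect, whereas a 10-fold higher number from compound 1 to compound 2 (1.00 log units; beyond the scatter) shows that a change at that ring can matter. Compound 4 is therefore expected to give 1000 nM, within 300 nM to 3000 nM, which means an estimated no change at the digits printed from compound 3 to compound 4 (within the scatter), nothing beyond the scatter.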

Compound 4, effective concentration (reported as EC, without a stated level of effect): 100 nM
The estimate for compound 4 lay 10-fold (1.00 log units) above the measured number; the whole stated range lies above it.
By their numbers in this assay, from the lowest: compounds 1 and 4 (each within the scatter of the next); then compounds 2 and 3 (each within the scatter of the next).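

In this assay, a single exchange on this aromatic carbon, meta to a large group, is enough to shift the result: fluoro in place of methyl gives a 10-fold lower number from compound 3 to compound 4 (1.00 log units; beyond the scatter). Replacing 4-methoxyphenyl with 3-fluorophenyl gives a 10-fold lower number from compound 2 to compound 4 (1.00 log units; beyond the scatter), whereas replacing 4-nitrophenyl with 3-fluorophenyl gives no change at the digits printed from compound 1 to compound 4 (within the scatter), so two differently substituted rings share the lower number. No evidence bears on what lies behind this shift.

Going by these compounds, whether chloro or an amine on this aromatic carbon would match fluoro or methyl remains open. So does whether fluoro would give the same number on another carbon of this ring.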